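The source may report more compounds than this note shows. Statements on the series, on what has been measured and on what is new or still open speak of the compounds shown alone.

Measured so far in an assay on isolated protein for inhibition of Apoptosis regulator Bcl-2 (Homo sapiens), read by fluorescence polarization, with stated times of 5 min and 10 min; a higher number here means a weaker inhibitor, a lower number a stronger inhibitor:
compound 1 `COc1ccc(NC(=O)[C@H]2CC=C(CCC=C(C)C)C[C@@H]2c2ccccc2)cc1`, > 23000 nM
compound 2 `COc1ccc(NC(=O)[C@@H]2CC=C(CCC=C(C)C)C[C@H]2c2ccccc2)cc1`, > 23000 nM
compound 3 `CON(C)C(=O)[C@@H]1CC2=C(CCCC2(C)C)C[C@H]1c1ccccc1`, > 23000 nM

Each of these three figures is a limit of the assay, not a number. Compound 1 gives > 23000 nM, a limit. Compound 2 gives > 23000 nM, the same limit. Compound 3 likewise returns > 23000 nM, again a limit. Compound 2 therefore stands nowhere readable on the scale: the step that the two limits leave unreadable from compound 1 to compound 2 cannot be sized, since both ends are limits (the limit of > 23000 nM in this assay, at which 3 of the 3 values shown sit), even though the two compounds differ only in configuration as drawn (the fact that compounds 1 and 2 differ only in the configuration as drawn).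

The next compound, compound 4 `CC(C)=CCCC1=CC[C@@H](C(=O)Nc2ccc(O)cc2)[C@H](c2ccccc2)C1`, differs from compound 2 by hydrogen in place of methyl on an oxygen on an aromatic ring. For the measured compounds named here, no measured step bears on this change: the only step in hand, a step that the two limits leave unreadable from compound 1 to compound 2, is itself unreadable, and none of the three values gives a number to move from. With every value at the limit, compound 4 is expected to return a limit as well, the step that the limit leaves unreadable from compound 2 to compound 4 being an estimate with no readable anchor. Compound 4 is estimated at 30000 nM, in the range 12000 nM to 100000 nM.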

Compound 4, inhibition constant: > 23000 nM
Compound 4 gave a limit, no number (the forecaster's own chance of this, stated with the estimate: 85%); the middle value lies beyond the limit too.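

No step can be read from compound 2 to compound 4, as both values are limits of the assay and not numbers. The compounds shown leave open whether going from methoxy to hydroxy changes inhibition at all, and where any of the four truly stands.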